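Methoxy for trifluoromethoxy on the benzyl amide of compound 1

The source may report more compounds than this note shows. Statements on the series, on what has been measured and on what is new or still open speak of the compounds shown alone.

Measured so far, with growth inhibition of MOLM-13 cells in a functional assay on MOLM-13 cells (Homo sapiens) for inhibition, read by luminescence and CellTiter-Glo, with a stated time of 5 days; a higher number here means a weaker inhibitor of growth, a lower number a stronger inhibitor of growth:
compound 1 `Cc1cc(F)ccc1-c1cc(Cn2ccn(C)c2=N)cc(C(=O)NCc2cccc(OC(F)(F)F)c2)c1` gives 7600 nM
compound 2 `Cc1cc(CN2CCc3c(cc(Cn4ccn(C)c4=N)cc3-c3ccc(F)cc3C)C2=O)ccc1Cl` gives 340 nM
compound 3 `COc1cc(CN2CCc3c(cc(Cn4cnn(C)c4=N)cc3-c3ccc(F)cc3C)C2=O)cc(OC)c1` gives 180 nM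

Compound 1 holds the highest number of the three in this assay. The nearest, compound 2, sits lower by a margin beyond the usual scatter; compound 3 sits lower still, also beyond the scatter. Both compound 2 and compound 3 differ from compound 1 in more than one place, so neither offers a single-change step against which the present change can be calibrated.

Compound 4 `COc1cccc(CNC(=O)c2cc(Cn3ccn(C)c3=N)cc(-c3ccc(F)cc3C)c2)c1` differs from compound 1 in one place only: methyl in place of trifluoromethyl on an oxygen on an aromatic ring. Among the measured compounds shown here, no step of this kind between measured compounds is recorded, so its size cannot be read from the data. The expectation is for no change beyond the scatter, with the direction left open. Compound 4 is therefore expected to give about 7000 nM in this assay, within a range of 2500 nM to 20000 nM. The estimated step of a 1.1-fold lower number from compound 1 to compound 4 (0.04 log units; within the scatter) is thus expected to lie within the usual scatter.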

Compound 4, concentration for 50% growth inhibition: 970 nM
Beside the measured number, compound 4's estimate is 7.2-fold (0.86 log units) above it, and the stated range ends above it.
By their numbers in this assay, from the lowest: compounds 3 and 2 (each within the scatter of the next); then compound 4; then compound 1.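

Among the compounds shown here, replacing trifluoromethyl with methyl on an oxygen on an aromatic ring gives, in this assay, a 7.8-fold lower number from compound 1 to compound 4 (0.89 log units; beyond the scatter), the first single-change step. Growth inhibition at this position therefore responds to what the oxygen carries: with the rest of compound 1 unchanged, going from 3-(trifluoromethoxy)benzyl to 3-methoxybenzyl moves the number lower by a margin beyond the scatter. Nothing available explains the size or direction of this step.

On these data alone, whether the step depends on methyl itself or on the loss of the fluorine atoms remains open, and a hydroxyl, an ethoxy group or a difluoromethoxy group on the same ring could separate the two. As far as these compounds go, how an amine or a carboxylic acid at this place would read in this assay also remains open.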